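Working notes: cytotoxicity and the difluorophenyl change

The compounds below may be only part of what the source reports. "The series", "measured", "known", "first", "only" and "open" are said of these compounds alone.

Measured so far:
compound 1 `Cc1ccc2cc(CN(Cc3ccc(F)cc3)Cc3ccc(C(C)(C)C)cc3)c(=O)[nH]c2c1`, > 33000 nM
compound 2 `Cc1ccc2cc(CN(Cc3ccc(F)cc3)Cc3ccc(C(F)(F)F)cc3)c(=O)[nH]c2c1`, > 33000 nM

In a toxicity assay on MDCK cells (Canis lupus familiaris) for cytotoxicity, read by crystal violet staining, with a stated time of 48 h (on this read-out higher numbers stand for lower toxicity in this test and lower numbers for higher toxicity in this test), compound 1 gives > 33000 nM, which is a limit of the assay and not a number. Compound 2 gives > 33000 nM in this assay, again a limit. Within the data shown here, the one measured step, a step that the two limits leave unreadable from compound 1 to compound 2, therefore cannot be sized, since both values sit at the limit of > 33000 nM in this assay, at which 2 of the 2 values shown sit. On the numbers shown compound 1 stands at that limit and nowhere more precise.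

The unmeasured compound 3 `Cc1ccc2cc(CN(Cc3ccc(C(C)(C)C)cc3)Cc3cc(F)cc(F)c3)c(=O)[nH]c2c1` differs from compound 1 in 3,5-difluorophenyl in place of 4-fluorophenyl on a saturated chain carbon bound to an amine nitrogen. Among the measured compounds shown here, no measured step touches this change: the only recorded step, a step that the two limits leave unreadable from compound 1 to compound 2, concerns a different part of the molecule and is itself unreadable. With both measured values at the limit, there is no basis for expecting compound 3 to move away from it. The step that the limit leaves unreadable from compound 1 to compound 3 is expected to be none beyond the scatter. For compound 3 the estimate in this assay is 40000 nM, within 20000 nM to 100000 nM, most likely reported again only as a limit.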

Compound 3, half-maximal cytotoxic concentration: > 33000 nM
Compound 3 ended at the assay's limit; the forecaster's own chance of this, stated with the estimate: 85%; the middle value does not contradict the limit.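

In this assay compound 3 gives > 33000 nM, a limit of the assay and not a number, so no new step can be read between compound 1 and compound 3. The compounds shown leave open whether any change in this series brings the half-maximal cytotoxic concentration away from the only level seen so far: the limit of > 33000 nM in this assay, at which 3 of the 3 values shown sit.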